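Compound 3 to compound 4: methyl to trifluoromethyl

The source may hold more compounds than are shown below. What is called first, only, known or untested is meant among the compounds shown, and "the series" means these compounds.

In a functional assay on U-937 cells (Homo sapiens) for antiproliferative activity, read by MTT assay, with a stated time of 72 h (a lower number here means a stronger inhibitor, a higher number a weaker inhibitor), compound 3 (`Cc1ccc(-c2noc(CCCCCCC(=O)Nc3ccccc3N)n2)cc1`) gives 460 nM and compound 2 (`Nc1ccccc1NC(=O)CCCCCCc1nc(-c2ccccc2)no1`) gives 730 nM as a value within the scatter of it. Measured against compound 3, compound 1 (`O=C(CCCCCCc1nc(-c2ccc(C(F)(F)F)cc2)no1)NO`) stands clearly apart with a higher number at 2870 nM in this assay as well. Among the compounds with values here, compound 1 carries the 4-(trifluoromethyl)phenyl group but has a different chain end, so it gives no direct step for the present question.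

The next structure is compound 4 (`Nc1ccccc1NC(=O)CCCCCCc1nc(-c2ccc(C(F)(F)F)cc2)no1`), and the difference from compound 3 is trifluoromethyl in place of methyl on an aromatic carbon in one swap: trifluoromethyl in place of methyl on an aromatic carbon, para to a large group.

Within the data shown here, only one measured step bears directly on this place. It is a 1.6-fold lower number from compound 2 to compound 3 (0.20 log units; within the scatter) (methyl in place of hydrogen on an aromatic carbon), and it stays within the scatter. The series therefore shows little response to this substituent so far, on that single pair. As far as these compounds go, no step beyond the scatter is expected in this assay and the direction remains open. The estimated step is a 1.3-fold higher number from compound 3 to compound 4 (0.12 log units; within the scatter) as a working figure. For compound 4 the expected value is 600 nM with an estimated range from 250 nM to 1500 nM on this basis.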

Compound 4, half-maximal inhibitory concentration: 5280 nM
The estimate for compound 4 lay 8.8-fold (0.94 log units) below the measured number, and the stated range ends below it.
By their numbers in this assay, from the lowest: compounds 3 and 2 (each within the scatter of the next); then compounds 1 and 4 (each within the scatter of the next).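

In this assay, this aromatic carbon no longer looks indifferent to substitution: methyl in place of hydrogen stayed within the scatter (a 1.6-fold lower number from compound 2 to compound 3 (0.20 log units; within the scatter)), whereas trifluoromethyl gives an 11-fold higher number from compound 3 to compound 4 (1.06 log units; beyond the scatter) and, measured against hydrogen, a 7.2-fold higher number from compound 2 to compound 4 (0.86 log units; beyond the scatter). Among compounds 2, 3 and 4, the response therefore depends on which group sits at this carbon, and occupation of the position alone does not produce the shift. With the 4-(trifluoromethyl)phenyl group held constant, the swap at the chain end gives a 1.8-fold higher number from compound 1 to compound 4 (0.26 log units; within the scatter), which is within the scatter, so this single pair does not separate the 2-aminophenyl and hydroxy ends; no measurement at hand explains the large step at the aromatic carbon.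

As far as these compounds go, whether the shift is particular to trifluoromethyl or also appears with a chlorine, a methoxy group or a nitrile at this carbon remains open. Within the data shown here, it is also open whether the two chain ends would stay within the scatter of each other with methyl or hydrogen on the ring, since the only direct comparison of them carries trifluoromethyl.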